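From compound 2 to compound 3: one group exchanged

The source may hold more compounds than are shown below. What is called first, only, known or untested is meant among the compounds shown, and "the series" means these compounds.

Of the compounds shown here, two have been measured in an in vivo ADME assay on the whole organism (strain Sprague-Dawley) for pharmacokinetics, with Rattus norvegicus as the target, at a dose of 2 mg/kg by the intravenous route; a lower number here means slower removal, a higher number faster removal of the compound. Compound 1 `N#Cc1cc(Cl)cc(Oc2cc(OCc3noc4nc(N)ccc34)ccc2Cl)c1` gives 93.4 mL/min/kg, and compound 2 `N#Cc1cc(Cl)cc(Oc2cc(OCc3n[nH]c4nc(N)ccc34)cc(F)c2Cl)c1` gives 10 mL/min/kg, the lower of the two numbers by a gap beyond the scatter. Compound 3 `N#Cc1cc(Cl)cc(Oc2cc(OCc3noc4nc(N)ccc34)cc(F)c2Cl)c1` departs from compound 2 in one place, on a saturated chain carbon bound to an oxygen on an aromatic ring: a group of 10 heavy atoms (6 carbon, 3 nitrogen, 1 oxygen; one five-membered aromatic ring with 2 hetero atoms, one six-membered aromatic ring with 1 hetero atom) in place of a group of 10 heavy atoms (6 carbon, 4 nitrogen; one five-membered aromatic ring with 2 hetero atoms, one six-membered aromatic ring with 1 hetero atom), on a saturated chain carbon bound to an oxygen on an aromatic ring. Within the data shown here, no measured pair isolates this exchange, so any forecast is uncertain. The entering group is also carried by compound 1, which stands at 93.4 mL/min/kg, and a rise beyond the scatter is therefore expected in this assay. The expected size of that rise is a 4.5-fold higher number from compound 2 to compound 3 (0.65 log units; beyond the scatter). Compound 3 is expected at 45 mL/min/kg, with an estimated range from 18 mL/min/kg to 90 mL/min/kg.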

Compound 3, clearance: 44.9 mL/min/kg
For compound 3 the middle estimate is 1.0-fold (0.00 log units) above the measured one; low and high end bracket the measured number.
By their numbers in this assay, from the lowest: compound 2; then compound 3; then compound 1.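

In this assay, the exchange on the saturated chain carbon bound to an oxygen on an aromatic ring now stands alone, with the fluoro held in place: the group with 3 nitrogen and 1 oxygen, in place of the group with 4 nitrogen, gives a step beyond the scatter (a 4.5-fold higher number from compound 2 to compound 3 (0.65 log units; beyond the scatter)). Fluoro in place of hydrogen on an aromatic carbon, with that group held in place, also gives a step beyond the scatter (a 2.1-fold lower number from compound 1 to compound 3 (0.32 log units; beyond the scatter)), so each of the two changes separating compound 1 and compound 2 has its own effect on the number, in the same direction. Nothing at hand bears on the reason for either step. As far as these compounds go, whether fluoro has the same effect alongside the group of compound 2 remains open. So does the outcome with chloro or methoxy in place of that fluoro.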